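Replacing a methylpiperidine with thiomorpholine on a tertiary amide

The compounds below may be only part of what the source reports. "The series", "measured", "known", "first", "only" and "open" are said of these compounds alone.

Measured compounds:
- Compound 1, `CC1CCC(NC(=O)c2ccc(C#Cc3ccccc3)nc2)CC1`: 1200 nM
- Compound 2, `O=C(NCc1ccsc1)c1ccc(C#Cc2ccccc2)nc1`: 140 nM
- Compound 3, `CC1CCN(C(=O)c2ccc(C#Cc3ccccc3)nc2)CC1`: 130 nM

All three compounds share a core in which a carbonyl group carries a nitrogen-based substituent. In a functional assay on BHK cells for positive allosteric modulation of metabotropic glutamate receptor 5 (Homo sapiens), read by FLIPR and calcium flux (on this read-out higher numbers stand for an effect only at larger amounts of compound and lower numbers for an effect already at smaller amounts), compound 3 shows the lowest of the three numbers, but the step of a 1.1-fold lower number from compound 2 to compound 3 (0.03 log units; within the scatter) lies within the scatter, so the two cannot be ranked. Compound 1 stands apart, with the steps of an 8.6-fold lower number from compound 1 to compound 2 (0.93 log units; beyond the scatter) and a 9.2-fold lower number from compound 1 to compound 3 (0.97 log units; beyond the scatter) both beyond the scatter.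

Compound 4, `O=C(c1ccc(C#Cc2ccccc2)nc1)N1CCSCC1`, differs from compound 3 in one place: thiomorpholin-4-yl in place of 4-methylpiperidin-1-yl on a carbonyl carbon. Both compound 3 and compound 4 keep a ring-closed nitrogen on the carbonyl, as in the step from compound 1 to compound 3, so that large step does not directly bear on this change. The step of a 1.1-fold lower number from compound 2 to compound 3 (0.03 log units; within the scatter) shows that exchanging one substituent for another of similar size can leave the number unchanged. Going by the values given here, no measured pair swaps one such ring for another, so the expectation for this assay rests on this indirect evidence, and a small step in either direction, likely within or near the scatter, is expected.

Compound 4 is therefore estimated at 250 nM, within a range of 80 nM to 800 nM, corresponding to an expected step of a 1.9-fold higher number from compound 3 to compound 4 (0.28 log units; within the scatter).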

Compound 4, half-maximal effective concentration: 46 nM
Compound 4: the middle estimate sits 5.4-fold (0.74 log units) above what was measured; measured number below the stated range.
By their numbers in this assay, from the lowest: compound 4; then compounds 3 and 2 (each within the scatter of the next); then compound 1.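

In this assay, the ring on the carbonyl carbon is not freely interchangeable: the only ring-for-ring swap among these compounds gives a 2.8-fold lower number from compound 3 to compound 4 (0.45 log units; beyond the scatter), a change beyond the scatter. Compound 4 also separates from the two compounds that keep the amide hydrogen, with a 3.0-fold lower number from compound 2 to compound 4 (0.48 log units; beyond the scatter) and a 26-fold lower number from compound 1 to compound 4 (1.42 log units; beyond the scatter), so it now has the lowest number of the four, whereas compound 2 and compound 3 could not be ranked. No measurement shown here explains why the number falls with this swap.

The swap removes the 4-methyl group and brings a sulfur atom into the ring at once, so the compounds shown cannot say which of these two differences matters. Plain piperidin-1-yl, with a ring carbon in place of the sulfur and no methyl group, would help separate the two, and morpholin-4-yl, with an oxygen atom in place of the sulfur, would show whether this ring position needs sulfur specifically.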